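Series notes: benzimidazole-free description, compound 2 to compound 3

This account rests on a few compounds, and the source may have more. Where it says the series, first, only, none or still open, it means among the compounds named here.

Measured so far:
- compound 1 `Oc1cccc2c1nc(COc1ccc(Cl)cc1)n2CCCC1CCCNC1`: 5300 nM
- compound 2 `Clc1ccc(OCc2nc3ccccc3n2CCCC2CCCNC2)cc1`: 700 nM

Within the data shown here, compound 2 gives the lowest number of the two measured in an assay on isolated protein for binding affinity to Neuropeptide Y receptor type 1 (Homo sapiens); a lower number here means a stronger inhibitor, a higher number a weaker inhibitor; its nearest neighbour is compound 1, and the only measured step, a 7.6-fold lower number from compound 1 to compound 2 (0.88 log units; beyond the scatter), separates them. Compound 3 `Clc1ccc(OCc2nc3c(OCCCC4CCNCC4)cccc3n2CCCC2CCCNC2)cc1` has not yet been measured. It differs from compound 2 in one place: 3-(piperidin-4-yl)propoxy in place of hydrogen on an aromatic carbon.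

Among the measured compounds shown here, the single measured step bears only indirectly on this change. It shows that the same aromatic carbon tolerates a hydrogen far better than a hydroxy, as seen in a 7.6-fold lower number from compound 1 to compound 2 (0.88 log units; beyond the scatter), so this position is sensitive to what sits there. Nothing measured tells how a long alkoxy chain carrying a second basic ring is received at that carbon, and the hydroxy result cannot be carried over to it. For the measured compounds named here, with no direct precedent, the expectation is kept near compound 2 with a wide range.

Compound 3 is therefore estimated at 600 nM, with a range from 120 nM to 3000 nM; this corresponds to an expected step of a 1.2-fold lower number from compound 2 to compound 3 (0.07 log units; within the scatter), which is not expected to lie clearly beyond the scatter in either direction.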

Compound 3, inhibition constant: 152 nM
Compound 3: middle estimate off by 3.9-fold (0.60 log units), on the high side, and the stated range covers the measured number.
By their numbers in this assay, from the lowest: compound 3; then compound 2; then compound 1.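

In this assay this aromatic carbon proves able to take far more than a hydrogen, since 3-(piperidin-4-yl)propoxy in place of hydrogen gives a 4.6-fold lower number from compound 2 to compound 3 (0.66 log units; beyond the scatter) and not a loss. The oxygen on the ring is also not penalised in every form: 3-(piperidin-4-yl)propyl in place of the hydrogen on that oxygen gives a 35-fold lower number from compound 1 to compound 3 (1.54 log units; beyond the scatter) and so reverses the picture left by the free hydroxy, where the earlier step was a 7.6-fold lower number from compound 1 to compound 2 (0.88 log units; beyond the scatter) in favour of plain hydrogen. No supporting data on hand bear on why these steps arise.

The compounds shown leave open which part of the new group accounts for the gain, the chain or the piperidine ring, and a plain propoxy or methoxy group at this carbon would begin to separate the two. Also open, from the compounds shown here alone, are how a shorter or longer chain compares with the propoxy link, and whether an open-chain amine such as dimethylamino at the end of the chain can stand in for the piperidine ring.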